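Truncating the aryl amine substituent on the carbamate core

This account rests on a few compounds, and the source may have more. Where it says the series, first, only, none or still open, it means among the compounds named here.

Compound 1 `O=C(OC(C(F)(F)F)C(F)(F)F)N1CCN(Cc2ccc(C(F)(F)F)cc2N2C[C@H]3CC[C@@H](C2)O3)CC1` and compound 2 `O=C(OC(C(F)(F)F)C(F)(F)F)N1CCN(Cc2ccc(C(F)(F)F)cc2N2[C@@H]3CC[C@H]2COC3)CC1` share the same core and differ only in the group carried on the aromatic carbon. In an assay on brain for inhibition of Monoglyceride lipase (Mus musculus), with a stated time of 30 min (on this read-out lower numbers stand for stronger inhibition and higher numbers for weaker inhibition), compound 1 gives 14 nM and compound 2 gives 48 nM. Within the data shown here, with the step of a 3.4-fold higher number from compound 1 to compound 2 (0.54 log units; beyond the scatter) compound 2 stands as the highest of the two numbers so far, compound 1 being its only neighbour.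

Compound 3 `O=C(OC(C(F)(F)F)C(F)(F)F)N1CCN(Cc2ccc(C(F)(F)F)cc2N2CC[C@H](O)C2)CC1` is the next member. Its change from compound 2 is a group of 6 heavy atoms (4 carbon, 1 nitrogen, 1 oxygen; one five-membered non-aromatic ring with 1 hetero atom) in place of a group of 8 heavy atoms (6 carbon, 1 nitrogen, 1 oxygen; one five-membered non-aromatic ring with 1 hetero atom, one six-membered non-aromatic ring with 2 hetero atoms), on an aromatic carbon. The entering group has one ring where the leaving group has two and brings one hydrogen-bond donor where the leaving group has none.

Among the measured compounds shown here, the single measured step, a 3.4-fold higher number from compound 1 to compound 2 (0.54 log units; beyond the scatter), exchanges one two-ring group for another of the same size and does not probe removal of a ring or the introduction of a hydroxyl; it shows only that rearranging the group at this position costs a modest amount. A larger shift in the same direction is taken as the more likely outcome. Compound 3 is therefore expected to show a step of a 3.1-fold higher number from compound 2 to compound 3 (0.49 log units; beyond the scatter). For compound 3 the estimate in this assay is 150 nM, with a range from 40 nM to 600 nM.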

Compound 3, half-maximal inhibitory concentration: 15 nM
Compound 3: middle estimate off by 10-fold (1.00 log units), on the high side; the whole stated range lies above it.
By their numbers in this assay, from the lowest: compounds 1 and 3 (each within the scatter of the next); then compound 2.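

In this assay, two rings are not needed at this place on the aromatic ring for the lower numbers of the series: the change to the 3-hydroxypyrrolidin-1-yl group, with one ring and one hydrogen-bond donor, gives a 3.2-fold lower number from compound 2 to compound 3 (0.51 log units; beyond the scatter) and so reverses the loss seen with the two-ring group of compound 2. Read against the other two-ring group, the same kind of exchange gives a 1.1-fold higher number from compound 1 to compound 3 (0.03 log units; within the scatter) and stays within the scatter, so the smaller group and the two-ring group of compound 1 cannot be told apart on this read-out, and the outcome of removing a ring depends on which two-ring group leaves. No independent measurement accounts for either step.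

As far as these compounds go, whether the hydroxyl itself matters remains open, since compound 3 differs from compounds 1 and 2 in ring count, group size and donor count at once; an unsubstituted pyrrolidin-1-yl or a 3-methoxypyrrolidin-1-yl group would separate these changes. From the compounds shown here alone, the role of the defined stereocentre also remains open, and the mirror-image 3-hydroxypyrrolidin-1-yl group would address it.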